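A Methyl Replaces Fluoro on the Benzyl Ring

This account rests on a few compounds, and the source may have more. Where it says the series, first, only, none or still open, it means among the compounds named here.

Compound 1, `N=C(NCc1ccc(O)cc1)[C@@H]1CCC(=O)N1Cc1ccccc1`, gives 35.4% in a functional assay on SH-SY5Y cells (Homo sapiens) for cytotoxicity, read by MTT assay, with stated times of 8 h, 30 min and 12 h, tested at 0.5 uM; a lower number here means a weaker effect, a higher number a stronger effect of the compound at the concentration tested.
Compound 2, `N=C(NCc1ccc(O)cc1)[C@@H]1CCC(=O)N1Cc1ccc([N+](=O)[O-])cc1`, gives 31.3%.
Compound 3, `N=C(NCc1ccc(O)cc1)[C@@H]1CCC(=O)N1Cc1ccc(F)cc1`, gives 42%.

For the measured compounds named here, compound 3 shows the highest of the three numbers in this assay, though its standing is narrow: the step of a number 6.6 percentage points higher from compound 1 to compound 3 (within the scatter) lies within the scatter, and only the step of a number 10.7 percentage points higher from compound 2 to compound 3 (beyond the scatter) reaches beyond it, and then only modestly. Compound 4, `Cc1ccc(CN2C(=O)CC[C@H]2C(=N)NCc2ccc(O)cc2)cc1`, has not yet been measured. It differs from compound 3 by methyl in place of fluoro on an aromatic carbon. Going by the values given here, no measured step swaps methyl for another group, so the only bearing comes from the two steps that altered the same aromatic carbon, a number 6.6 percentage points higher from compound 1 to compound 3 (within the scatter) and a number 10.7 percentage points higher from compound 2 to compound 3 (beyond the scatter). Three different groups at that carbon gave numbers within a narrow band, the widest gap among them being only modest, and nothing in the measured compounds points to methyl behaving differently from hydrogen or fluoro there. The step of a number 4 percentage points lower from compound 3 to compound 4 (within the scatter) is therefore expected to lie within the scatter, in either direction. In this assay compound 4 is accordingly estimated at 38%, with a range from 28% to 48%.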

Compound 4, a percentage reported as activity, at one concentration (the size of the read-out at that concentration, not a potency): 21.9%
Beside the measured number, compound 4's estimate is 16.1 percentage points above it; the whole stated range lies above it.
By their numbers in this assay, from the lowest: compounds 4, 2, 1 and 3 (each within the scatter of the next, the first and the last beyond it).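

The aromatic carbon that had given only small steps in this assay now shows a clear response to the group it carries, with methyl in place of fluoro giving the largest step seen at this carbon so far (a number 20.1 percentage points lower from compound 3 to compound 4 (beyond the scatter)). Methyl also separates from hydrogen (a number 13.5 percentage points lower from compound 1 to compound 4 (beyond the scatter)), so 4-methylbenzyl stands apart from both the unsubstituted benzyl and 4-fluorobenzyl compounds, and a single heavy atom exchanged for another is enough to move the number beyond the scatter. The step from the nitro compound stays inside the scatter (a number 9.4 percentage points lower from compound 2 to compound 4 (within the scatter)), so those two cannot be set in order, and nothing measured here explains why fluoro and methyl, alike in their count of heavy atoms, part so far.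

On these data alone, whether the low number belongs to methyl alone or extends to a longer chain such as ethyl, or to a methoxy group or an amine on the same carbon, stays open. The compounds shown also leave unsettled whether methyl would give a similar step on another carbon of the ring or at another concentration.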